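A few compounds are considered here, and "the series" means these few. Any claim that something is new, unique, unknown or untested is made for them only; others in the source may bear on it.

Measured so far in a functional assay on the whole organism (strain C57BL/6) for inhibition, with Mus musculus as the target, read by paw edema, with stated times of 1 h and 4 h, at a dose of 100 mg/kg by the oral route; on this read-out higher numbers stand for more inhibition at the one dose given (going by the name of the read-out) and lower numbers for less inhibition:
compound 1 `COc1ccc(NC(=O)CCc2nc(Cc3ccc(NC(C)=O)cc3)no2)cc1` gives 49.3%
compound 2 `CC(=O)Nc1ccc(Cc2noc(CCC(=O)Nc3ccc(C(F)(F)F)cc3)n2)cc1` gives 37%

Among the measured compounds shown here, compound 1 stands highest of these two numbers; its only neighbour is compound 2, reached by a number 12.3 percentage points lower from compound 1 to compound 2 (beyond the scatter), a step beyond the scatter, in which trifluoromethyl took the place of methoxy on an aromatic carbon.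

Compound 3 `CC(=O)Nc1ccc(Cc2noc(CCC(=O)NCc3ccccc3)n2)cc1` has not yet been measured. It differs from compound 1 by benzyl in place of 4-methoxyphenyl on an amide-type nitrogen. For the measured compounds named here, the one measured step bears on this only loosely: it shows that exchanging the group on the aromatic ring of the amide substituent lowered the read-out by a modest amount, and the change to compound 3 likewise removes the methoxy, while also replacing the whole 4-methoxyphenyl by benzyl. Going by the values given here, no measured pair shows that exact exchange. A modest downward step is therefore expected, a number 11.3 percentage points lower from compound 1 to compound 3 (beyond the scatter). Compound 3 is estimated at 38%, with a range from 20% to 55%.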

Compound 3, a percentage reported as inhibition, in the whole organism at one dose (the size of the read-out at that dose, not a potency): 76.7%
Compound 3: middle estimate off by 38.7 percentage points, on the low side, outside the stated range (above it).
By their numbers in this assay, from the lowest: compound 2; then compound 1; then compound 3.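

In this assay, among the compounds shown here, the group on the amide-type nitrogen turns out to govern the read-out far more than the one earlier step could show, since that step only exchanged one ring substituent for another. Benzyl in place of 4-methoxyphenyl gives a number 27.4 percentage points higher from compound 1 to compound 3 (beyond the scatter), and benzyl in place of 4-(trifluoromethyl)phenyl gives a number 39.7 percentage points higher from compound 2 to compound 3 (beyond the scatter), so both changes at this position raise the read-out, the second by more. No measurement here explains this rise.

The compounds shown cannot separate the loss of the ring substituent from the change of phenyl to benzyl, a question that unsubstituted phenyl or 4-methoxybenzyl on this nitrogen would address. On these data alone, whether a longer chain such as 2-phenylethyl would continue the rise also stays open.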